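Swapping Chloro for Bromo on Two Related Cores

A few compounds are considered here, and "the series" means these few. Any claim that something is new, unique, unknown or untested is made for them only; others in the source may bear on it.

Compound 1 `O=C1/C(=C/c2ccc(Cl)cc2)Cc2ccccc21` and compound 2 `O=C1/C(=C/c2ccc(Br)cc2)Cc2ccccc21` share one core and differ in a single group on an aromatic ring. In a functional assay on L1210 cells (Mus musculus) for inhibition (on this read-out higher numbers stand for weaker inhibition and lower numbers for stronger inhibition), compound 1 gives 54100 nM. Measured the same way, compound 2 gives 64800 nM. The structural change between them is bromo in place of chloro on an aromatic carbon and the step it made was a 1.2-fold higher number from compound 1 to compound 2 (0.08 log units; within the scatter).

Compound 3 `O=C1/C(=C/c2cccc(Cl)c2)CCCc2ccccc21` is built on a different core; the difference between the two cores is not broken down here. In this assay compound 3 gives 52300 nM, a number that lies within the usual scatter of the numbers for compound 1 and compound 2, so no ordering among the three can be claimed.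

Compound 4 `O=C1/C(=C/c2cccc(Br)c2)CCCc2ccccc21` has not yet been measured. It differs from compound 3 by bromo in place of chloro on an aromatic carbon. Among the measured compounds shown here, this is the same kind of change as the one between compound 1 and compound 2, but not the same change: in compound 2 the bromo sits para to a large group, whereas in compound 4 it sits meta to a large group. Because the earlier swap gave only a 1.2-fold higher number from compound 1 to compound 2 (0.08 log units; within the scatter), the step from compound 3 to compound 4 is expected to be similarly small, about a 1.1-fold higher number from compound 3 to compound 4 (0.06 log units; within the scatter). Compound 4 is therefore estimated to give about 60000 nM in this assay, with a likely range from 35000 nM to 100000 nM.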

Compound 4, half-maximal inhibitory concentration: 51000 nM
For compound 4 the middle estimate is 1.2-fold (0.07 log units) above the measured one, and the stated range covers the measured number.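

In this assay, putting bromo in place of chloro on the core of compound 3 produced a 1.0-fold lower number from compound 3 to compound 4 (0.01 log units; within the scatter), so this swap leaves the number effectively unmoved on this core. The same swap on the core of compound 1 was just as small, and the two steps do not differ by more than repeated measurements would: the same change on two cores in this assay, a 1.2-fold higher number (0.08 log units; within the scatter) from compound 1 to compound 2 and a 1.0-fold lower number (0.01 log units; within the scatter) from compound 3 to compound 4, 1.2-fold (0.09 log units) apart, within the scatter of two such steps. This shows that, across these two pairs, the swap carried from one core to the other as a step too small to read; it does not show that the swap has the same effect on both cores, as any small real difference would be hidden in the scatter, the halogen does not sit in the same place on the ring in the two pairs, and two pairs make a very small sample.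

The compounds shown leave open whether a group of a different kind on this aromatic ring, such as an amine, a carboxylic acid or a longer chain, would shift the number by more than the scatter. They also leave open whether the swap from chloro to bromo would stay this small on other cores.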